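Pyridin-2-yl for phenyl on the amine side chain

The source may hold more compounds than are shown below. What is called first, only, known or untested is meant among the compounds shown, and "the series" means these compounds.

Measured compounds:
compound 1, `COc1cccc(-c2c(C)n(Cc3ccccc3F)c3nc(C(C)(C)C)c(CN(C)Cc4ccccn4)n3c2=O)c1`, 11 nM
compound 2, `COc1cccc(-c2c(C)n(Cc3ccccc3F)c3nc(C(C)(C)C)c(CNCc4ccccc4)n3c2=O)c1`, 240 nM

For the measured compounds named here, in an assay on isolated protein for binding affinity to Gonadotropin-releasing hormone receptor (Homo sapiens) (on this read-out lower numbers stand for stronger inhibition and higher numbers for weaker inhibition), compound 2 gives the higher of the two numbers so far; its nearest neighbour is compound 1, and the step from the one to the other, a 22-fold higher number from compound 1 to compound 2 (1.34 log units; beyond the scatter), lies well beyond the scatter. That step, however, changes two things at once, the loss of the methyl on the amine nitrogen together with the ring swap, so it bears only in part on the move to compound 3, `COc1cccc(-c2c(C)n(Cc3ccccc3F)c3nc(C(C)(C)C)c(CNCc4ccccn4)n3c2=O)c1`. Compound 3 differs from compound 2 by pyridin-2-yl in place of phenyl on a saturated chain carbon bound to an amine nitrogen. Since that ring swap is one part of the step from compound 1 to compound 2, a move in this assay back toward the lower number of compound 1 is expected, but smaller than the whole step. For compound 3 a step of a 3.4-fold lower number from compound 2 to compound 3 (0.54 log units; beyond the scatter) is therefore expected, giving an estimated 70 nM with a range from 20 nM to 240 nM.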

Compound 3, inhibition constant: 30 nM
The estimate for compound 3 lay 2.3-fold (0.37 log units) above the measured number, and the stated range covers the measured number.
By their numbers in this assay, from the lowest: compound 1; then compound 3; then compound 2.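

In this assay the ring swap can now be read alone: pyridin-2-yl in place of phenyl on a saturated chain carbon bound to an amine nitrogen gives an 8.0-fold lower number from compound 2 to compound 3 (0.90 log units; beyond the scatter) and so counts by itself, with the amine nitrogen carrying hydrogen in both compounds. The other part of the earlier double change, hydrogen in place of methyl on the amine nitrogen, gives a 2.7-fold higher number from compound 1 to compound 3 (0.44 log units; beyond the scatter) with pyridin-2-yl held constant, so both changes lie beyond the scatter and each contributes to the earlier step. Nothing available explains either step. From the compounds shown here alone, whether pyridin-3-yl or pyridin-4-yl would match pyridin-2-yl at this position remains open, as does the effect of an ethyl on the amine nitrogen. Also open, going by these compounds, is whether the methyl would matter equally with phenyl on the chain, since its effect is isolated here only with pyridin-2-yl.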